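Sulfonyl substituent changes in an aryl-alkyne phenoxyacetic acid series

The source may hold more compounds than are shown below. What is called first, only, known or untested is meant among the compounds shown, and "the series" means these compounds.

Two analogues sharing the same core have been measured in an assay on CHO cells for displacement of a labelled ligand from prostaglandin D2 receptor 2 (Homo sapiens), read by scintillation counting; a higher number here means a weaker inhibitor, a lower number a stronger inhibitor. Compound 1 `Cc1ccc(S(=O)(=O)Cc2ccccc2)cc1C#Cc1cc(Cl)ccc1OCC(=O)O` gives 5 nM. Compound 2 `CCS(=O)(=O)c1ccc(C)c(C#Cc2cc(Cl)ccc2OCC(=O)O)c1` gives 8.6 nM, the higher of the two numbers; the two compounds sit within the scatter of each other, as the step of a 1.7-fold higher number from compound 1 to compound 2 (0.24 log units; within the scatter) shows. Compound 3 `Cc1ccc(S(=O)(=O)NC(C)C)cc1C#Cc1cc(Cl)ccc1OCC(=O)O` has not been measured; it differs from compound 2 by isopropylamino in place of ethyl on a sulfonyl sulfur. Going by the values given here, the only measured step touching this sulfonyl sulfur, a 1.7-fold higher number from compound 1 to compound 2 (0.24 log units; within the scatter), stayed within the scatter, so the position tolerates the exchange of one substituent for another. Among the compounds with values here, no measured pair shows a sulfonamide replacing a sulfone, so the direction of the present change is unsupported by data. The expected step in this assay is a 1.7-fold higher number from compound 2 to compound 3 (0.24 log units; within the scatter), a small change that may not exceed the scatter. Compound 3 is therefore estimated at 15 nM, with a range of 4 nM to 60 nM.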

Compound 3, inhibition constant: 3.4 nM
Estimate against measurement, compound 3: 4.4-fold (0.64 log units) above; measured number outside the range, below it.
By their numbers in this assay, from the lowest: compounds 3, 1 and 2 (each within the scatter of the next, the first and the last beyond it).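

Exchanging ethyl for isopropylamino on the sulfonyl sulfur in this assay gives a 2.5-fold lower number from compound 2 to compound 3 (0.40 log units; beyond the scatter), so this position responds measurably to a substituent change, a modest effect that the earlier benzyl-to-ethyl exchange did not show beyond the scatter. The comparison with the benzyl sulfone gives a 1.5-fold lower number from compound 1 to compound 3 (0.17 log units; within the scatter), so the isopropylsulfamoyl group and the benzyl group cannot be ordered at this position, and the sulfonamide is accommodated without loss relative to that sulfone. No supporting data bear on the origin of the difference between compound 2 and compound 3.

The compounds shown do not separate the contribution of the sulfonamide nitrogen from that of the larger carbon group. An isopropyl group bound directly to the sulfonyl sulfur, together with ethylamino or dimethylamino on that sulfur, would address this.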